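Trifluoromethoxy to Carbamoyl on the Calcium Channel Series

A few compounds are considered here, and "the series" means these few. Any claim that something is new, unique, unknown or untested is made for them only; others in the source may bear on it.

Measured compounds:
compound 1 `COC(=O)c1cccc(C(=O)N2CCC(N(C3CC3)S(=O)(=O)c3cccc(C(F)(F)F)c3)CC2)c1` — "not determined" (no result reported)
compound 2 `NC(=O)c1cccc(C(=O)N2CCC(N(C3CC3)S(=O)(=O)c3cccc(C(F)(F)F)c3)CC2)c1` — "not determined" (no result reported)
compound 3 `O=C(c1ccc(OC(F)(F)F)cc1)N1CCC(N(C2CC2)S(=O)(=O)c2cccc(C(F)(F)F)c2)CC1` — 88%

Three compounds share a core in which a piperidine amide is joined to a cyclopropyl-bearing sulfonamide. In an assay on cells for inhibition of Voltage-dependent L-type calcium channel subunit alpha-1C (Homo sapiens), read by FLIPR and calcium flux, tested at 3 uM (on this read-out higher numbers stand for a stronger effect at the one concentration tested and lower numbers for a weaker effect), compound 1 gives "not determined" (no result reported), and compound 2 gives "not determined" (no result reported); for neither was a number obtained. That leaves compound 3 as the only one with a result: in this assay compound 3 gives 88%, a strong effect at the single concentration tested. Among the measured compounds shown here, since no other compound carries a number, compound 3 cannot be ranked against anything; it simply stands alone as the reference point.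

The next compound, compound 4 `NC(=O)c1ccc(C(=O)N2CCC(N(C3CC3)S(=O)(=O)c3cccc(C(F)(F)F)c3)CC2)cc1`, differs from compound 3 in one place: carbamoyl in place of trifluoromethoxy on an aromatic carbon. For the measured compounds named here, no measured pair shows what such a change does in this assay, so the expectation rests on compound 3 alone and on the nature of the swap.

A step downward of moderate size is expected from compound 3 to compound 4, a number 38 percentage points lower from compound 3 to compound 4 (beyond the scatter), somewhat beyond the usual scatter. For compound 4 the estimated value in this assay is therefore 50%, with a likely range from 15% to 80%.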

Compound 4, a percentage reported as inhibition, at one concentration (the size of the read-out at that concentration, not a potency): 0%
For compound 4 the middle estimate is 50 percentage points above the measured one; the measured number lies below the stated range.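

Among the compounds shown here, the first measured pair in this assay shows that this place on the aromatic ring, para to a large group, strongly influences the read-out: putting carbamoyl in place of trifluoromethoxy gives a number 88 percentage points lower from compound 3 to compound 4 (beyond the scatter) and leaves no measurable effect at the one concentration tested. The shared core is therefore not enough on its own to give the strong effect seen for compound 3, and in this pair the group at this single place makes the difference between a strong effect and none. Nothing measured here explains this large step, so it stands as an observation without a known cause.

This single pair cannot separate what is lost with trifluoromethoxy from what is gained with carbamoyl, and compound 1 and compound 2, which carry no number, offer no further comparison. From the compounds shown here alone, it also remains open where a methoxy group, an amine or a carboxylic acid at this same place would fall on the range from strong effect to none.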